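The source may hold more compounds than are shown below. What is called first, only, known or untested is meant among the compounds shown, and "the series" means these compounds.

Compound 1 `CN1CCC(CNS(=O)(=O)c2ccccc2Nc2cc(-c3ccc4ccn(C)c4c3)c3nccnc3c2)C1` gives 11 nM in an assay for inhibition of 6-phosphofructo-2-kinase/fructose-2,6-bisphosphatase 3 (Homo sapiens), read by ADP-Glo, with a stated time of 2 h; a higher number here means a weaker inhibitor, a lower number a stronger inhibitor.
Compound 2 `Cn1ccc2ccc(-c3cc(Nc4ccccc4S(N)(=O)=O)cc4nccnc34)cc21` gives 265 nM in this assay.
Compound 3 `CNC(=O)c1ccncc1Nc1cc(-c2ccc3ccn(C)c3c2)c2nccnc2c1` gives 83 nM in this assay.

Among these three, compound 3 holds the middle place: it sits below compound 2, the step from compound 2 to compound 3 being a 3.2-fold lower number from compound 2 to compound 3 (0.50 log units; beyond the scatter), while compound 1 lies well beneath it and remains the strongest inhibitor of the set. Compound 4 `Cn1cc(NC(=O)c2ccncc2Nc2cc(-c3ccc4ccn(C)c4c3)c3nccnc3c2)cn1` is the next compound, and it differs from compound 3 in one place: 1-methyl-1H-pyrazol-4-yl in place of methyl on an amide-type nitrogen. Among the measured compounds shown here, no measured step alters this amide nitrogen directly. For the measured compounds named here, the step from compound 1 to compound 2, a 24-fold higher number from compound 1 to compound 2 (1.38 log units; beyond the scatter), is the nearest precedent, since there a substituent on a nitrogen of the side arm was removed and a large loss followed; here a ring is added to a nitrogen of the side arm, so the direction would be the reverse. The step from compound 2 to compound 3 concerns the whole arm and gives less guidance. A modest gain in this assay is therefore expected for compound 4, smaller than the step from compound 1 to compound 2, with the step from compound 3 to compound 4 estimated as a 2.1-fold lower number from compound 3 to compound 4 (0.32 log units; beyond the scatter). Compound 4 is expected to give about 40 nM, within 12 nM to 130 nM.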

Compound 4, half-maximal inhibitory concentration: 33 nM
Compound 4: middle estimate off by 1.2-fold (0.08 log units), on the high side, and the stated range covers the measured number.
By their numbers in this assay, from the lowest: compound 1; then compound 4; then compound 3; then compound 2.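

Among the compounds shown here, the amide-type nitrogen of compound 3, which no earlier step had touched, proves open to change in this assay: replacing methyl with 1-methyl-1H-pyrazol-4-yl gives a 2.5-fold lower number from compound 3 to compound 4 (0.40 log units; beyond the scatter). For the compounds shown here, this gives the position a reading of its own, as the only earlier change of a substituent on a nitrogen, a 24-fold higher number from compound 1 to compound 2 (1.38 log units; beyond the scatter), took place on a sulfonamide nitrogen in a different arm and removed a group instead of enlarging one. The gain shows that an aromatic ring carried on this nitrogen is compatible with a lower number than methyl gives, but nothing available explains why the number falls.

On these data alone, it remains open whether the gain belongs to the aromatic ring itself, to its two ring nitrogens, to its N-methyl group or simply to a larger substituent on the amide-type nitrogen. The compounds shown also leave open how a phenyl ring, a longer alkyl chain or an amine such as the (1-methylpyrrolidin-3-yl)methyl group of compound 1 would fare on this nitrogen in this assay.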